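Two aryl sulfonyl chalcones and a thioether in a growth assay

This account rests on a few compounds, and the source may have more. Where it says the series, first, only, none or still open, it means among the compounds named here.

Measured compounds:
Compound 1 `O=C(/C(=C\c1ccc(F)c([N+](=O)[O-])c1)S(=O)(=O)c1ccc(Br)cc1)c1ccc(Br)cc1` gives 25000 nM.
Compound 2 `O=C(/C(=C\c1c(O)cc(O)cc1O)Sc1ccc(Br)cc1)c1ccc(Cl)cc1` gives 50000 nM.
Compound 3 `Cc1ccc(CS(=O)(=O)/C(=C/c2c(O)cc(O)cc2O)C(=O)c2ccc(Cl)cc2)cc1` gives > 100000 nM.

All three were tested in a functional assay on DU-145 cells (Homo sapiens) for inhibition, read by trypan blue exclusion, with a stated time of 96 h; a higher number here means a weaker inhibitor of growth, a lower number a stronger inhibitor of growth. Compound 1 and compound 2 sit close together; the numbers of compound 1 and compound 2 lie within the usual scatter of each other, so no order between them can be read. For compound 3 the assay reports only a limit, (the limit of > 100000 nM in this assay, at which 1 of the 3 values shown sits), and not a number. Compound 1 thus stands at the lower of the two numbers actually obtained, with compound 2 a short distance above it.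

Compound 4 `Nc1c(Br)cc(Br)cc1/C=C(\C(=O)c1ccc(Br)cc1)S(=O)(=O)c1ccc(Br)cc1` has not yet been measured in this assay. It differs from compound 1 at one place only (2-amino-3,5-dibromophenyl in place of 4-fluoro-3-nitrophenyl on a double-bonded chain carbon bound to a double-bonded chain carbon). The 4-fluoro-3-nitrophenyl of compound 1 leaves and a 2-amino-3,5-dibromophenyl enters on the double-bonded chain carbon. Within the data shown here, no pair of measured compounds separated by a single change is available to gauge such a step, and the two numbers that exist are both weak and near each other.

Compound 4 is therefore expected to stay close to compound 1, with a step of a 1.2-fold higher number from compound 1 to compound 4 (0.08 log units; within the scatter) that is estimated to lie within the scatter. For compound 4 the estimated value in this assay is 30000 nM, with a range from 8000 nM to 100000 nM.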

Compound 4, concentration for 50% growth inhibition: 25000 nM
For compound 4 the middle estimate is 1.2-fold (0.08 log units) above the measured one, within the range that was stated.
By their numbers in this assay, from the lowest: compounds 1, 4 and 2 (each within the scatter of the next). At a limit, above all of these: compound 3.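

Replacing 4-fluoro-3-nitrophenyl with 2-amino-3,5-dibromophenyl on a double-bonded chain carbon bound to a double-bonded chain carbon provides the only single-change comparison among the compounds shown: in this assay there is no change at the digits printed from compound 1 to compound 4 (within the scatter). The earlier compounds shown here could not show this, since none of them differed from another in one place only. The two groups share little beyond the six-membered aromatic ring, one bearing a nitro group and fluorine and the other an amine and two bromines, yet this exchange at this position leaves growth inhibition without a readable shift, and no measurement available here bears on why the two groups read alike.

Going by these compounds, whether the amine and the bromines of compound 4 matter separately remains open, as a single comparison cannot divide the change into its parts. Also open, on these data alone, is whether any other group at this place, such as a plain phenyl, a pyridine or a benzoic acid, would move the number away from the level of compound 1 at 25000 nM.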